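The source may hold more compounds than are shown below. What is called first, only, known or untested is meant among the compounds shown, and "the series" means these compounds.

Measured so far:
- compound 1 `Cc1ccc(OCC(=O)N(Cc2cccs2)c2cccnc2)cc1`: 198 nM
- compound 2 `CCN(Cc1cccs1)C(=O)C(C)Oc1ccc(C)cc1`: 889 nM

In an assay on HEK293 cells for agonist activity at transient receptor potential cation channel subfamily M member 8 (Homo sapiens), read by fluorescence and calcium flux, with a stated time of 15 min (on this read-out higher numbers stand for an effect only at larger amounts of compound and lower numbers for an effect already at smaller amounts), compound 1 gives 198 nM, the lower of the two numbers seen so far. Compound 2 gives 889 nM in this assay, a higher number, and the gap between the two lies beyond the usual scatter. For the measured compounds named here, no single-point step between measured compounds is available.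

The next compound, compound 3 `Cc1ccc(OCC(=O)N(Cc2cccs2)C(C)C)cc1`, is not yet measured in this assay. Its change from compound 1 is isopropyl in place of pyridin-3-yl on an amide-type nitrogen. Compound 2 also carries a small saturated group rather than an aromatic ring on the amide-type nitrogen, and since compound 2 gives 889 nM, a rise in the number for compound 3 is expected, of moderate size. The step of a 3.0-fold higher number from compound 1 to compound 3 (0.48 log units; beyond the scatter) is the expected outcome, towards a higher number. Compound 3 is therefore estimated at 600 nM in this assay, within a range of 200 nM to 2000 nM.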

Compound 3, half-maximal effective concentration: 70 nM
Compound 3: middle estimate off by 8.6-fold (0.93 log units), on the high side; the whole stated range lies above it.
By their numbers in this assay, from the lowest: compound 3; then compound 1; then compound 2.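

On the amide-type nitrogen, an aromatic ring is not required for activity in this assay, since isopropyl in place of pyridin-3-yl gives a 2.8-fold lower number from compound 1 to compound 3 (0.45 log units; beyond the scatter) and so moves the number down. This position therefore accepts a group with no ring, fewer heavy atoms and no hydrogen-bond acceptor, at least in the setting of the shared core. Nothing at hand explains why the number falls with this change.

The compounds shown leave open whether a cyclopropyl group, a tert-butyl group or a longer chain such as n-butyl on this nitrogen would lower the number further, and whether a plain phenyl ring would behave like pyridin-3-yl or like isopropyl. Also open, going by these compounds, is whether the same step would hold with an amine or a carboxylic acid elsewhere on the shared core.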